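Trimming a Chain: Compound 3 in a Toxicity Test

The source may hold more compounds than are shown below. What is called first, only, known or untested is meant among the compounds shown, and "the series" means these compounds.

compound 1 `CCCCCC(=O)OCCc1ccc(O)cc1`: 166000 nM
compound 2 `CCCCCCCCCCCCC(=O)OCCc1ccc(O)c(O)c1`: 13200 nM

In a toxicity assay on MRC5 cells (Homo sapiens) for inhibition, read by MTT assay, with a stated time of 72 h (on this read-out lower numbers stand for stronger inhibition and higher numbers for weaker inhibition), compound 2 gives 13200 nM, the lowest of the two numbers, and the gap up to compound 1 lies beyond the scatter. Compound 3 `CCCCCCCC(=O)OCCc1ccc(O)c(O)c1` departs from compound 2 by one change: hydrogen in place of pentyl on a saturated chain carbon, seven bonds along the chain from a carbonyl carbon. Going by the values given here, no measured pair isolates such a change, since compound 1 and compound 2 differ in more than one place. Among the compounds with values here, the only hint is that compound 1, which has the shorter chain of the two, reads 166000 nM. On that slender basis, a move toward a higher number, beyond the scatter, is expected, with a 3.4-fold higher number from compound 2 to compound 3 (0.53 log units; beyond the scatter) as the estimated step. For compound 3 the expected value is 45000 nM, with an estimated range from 18000 nM to 120000 nM.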

Compound 3, half-maximal inhibitory concentration: 104000 nM
Estimate against measurement, compound 3: 2.3-fold (0.36 log units) below, and the stated range covers the measured number.
By their numbers in this assay, from the lowest: compound 2; then compounds 3 and 1 (each within the scatter of the next).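

In this assay, going by these compounds alone, the chain change is read on its own for the first time: with the rest of the structure held fixed, hydrogen in place of pentyl on a saturated chain carbon, seven bonds along the chain from a carbonyl carbon, gives a 7.9-fold higher number from compound 2 to compound 3 (0.90 log units; beyond the scatter) and so moves toward weaker inhibition. This position is therefore not indifferent to the change, a point the earlier pair could not settle, as its two compounds differ in more than one place. No measurement shown here explains the shift.

Within the data shown here, only this one change is read at this position, so whether the number climbs evenly or abruptly as the chain shortens remains open. On these data alone, how a longer chain, an amine or a carboxylic acid in place of pentyl would read also remains unknown.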